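Varying the Dioxopyrrolidine Substituent on a Shared Core

This account rests on a few compounds, and the source may have more. Where it says the series, first, only, none or still open, it means among the compounds named here.

Among the measured compounds shown here, compound 1 `CC1C(=O)N(c2ccccc2C(=O)OCC2CCCN(CCCc3ccccc3)C2)C(=O)C1C` gives 6000 nM in a functional assay with Neuronal acetylcholine receptor; alpha3/beta4 (Homo sapiens) as the target (a lower number here means a stronger inhibitor, a higher number a weaker inhibitor), the highest number of the two measured so far. Compound 2 `CCCCCCCCC1CC(=O)N(c2ccccc2C(=O)OCC2CCCN(CCCc3ccccc3)C2)C1=O` gives 1300 nM in this assay, a lower number that lies beyond the usual scatter. Compound 3 `CC(C)C1CC(=O)N(c2ccccc2C(=O)OCC2CCCN(CCCc3ccccc3)C2)C1=O` differs from compound 1 by a group of 10 heavy atoms (7 carbon, 1 nitrogen, 2 oxygen; one five-membered non-aromatic ring with 1 hetero atom) in place of a group of 9 heavy atoms (6 carbon, 1 nitrogen, 2 oxygen; one five-membered non-aromatic ring with 1 hetero atom), on an aromatic carbon. For the measured compounds named here, no single-change step between measured compounds exists here, yet compound 2 with its 1300 nM suggests that a larger group on this ring can give a lower number. Compound 3 is expected to show a moderate decrease, a 1.7-fold lower number from compound 1 to compound 3 (0.23 log units; within the scatter), landing at an estimated 3500 nM with a range from 1200 nM to 10000 nM.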

Compound 3, half-maximal inhibitory concentration: 2500 nM
For compound 3 the middle estimate is 1.4-fold (0.15 log units) above the measured one; the measured number falls inside the stated range.
By their numbers in this assay, from the lowest: compounds 2 and 3 (each within the scatter of the next); then compound 1.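

In this assay, a ring carrying a single isopropyl group in place of the 3,4-dimethyl-2,5-dioxopyrrolidin-1-yl group gives a 2.4-fold lower number from compound 1 to compound 3 (0.38 log units; beyond the scatter) on the shared core, so this position does respond to the change, though modestly. Isopropyl in place of octyl on the saturated ring carbon gives a 1.9-fold higher number from compound 2 to compound 3 (0.28 log units; within the scatter) and thus does not separate the short group from the long chain. As far as these compounds go, how a hydroxyl, an amine or a phenyl ring at that ring carbon would read remains open. Nothing measured here accounts for these numbers.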